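A few compounds are considered here, and "the series" means these few. Any claim that something is new, unique, unknown or untested is made for them only; others in the source may bear on it.

Compound 3, `COc1ccc(CCCCCCCCOc2ccc(C[S+]([O-])c3cccc(C(=O)O)c3)nc2/C=C/C(=O)O)cc1`, gives 151 nM in an assay for binding affinity to leukotriene B4 receptor 1 (Homo sapiens); on this read-out higher numbers stand for weaker inhibition and lower numbers for stronger inhibition. Among the three compounds measured it carries the highest number: compound 2, `COc1ccc(CCCCCCCCOc2ccc(C[S+]([O-])c3cccc(NS(=O)(=O)c4ccccc4)c3)nc2/C=C/C(=O)O)cc1`, gives 147 nM, and the step of a 1.0-fold higher number from compound 2 to compound 3 (0.01 log units; within the scatter) lies within the scatter, while compound 1, `COc1ccc(CCCCCCCCOc2ccc(C[S+]([O-])c3ccccc3)nc2/C=C/C(=O)O)cc1`, gives 37 nM, and the step of a 4.1-fold higher number from compound 1 to compound 3 (0.61 log units; beyond the scatter) is beyond it.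

Compound 4, `COc1ccc(CCCCCCCCOc2ccc(C[S+]([O-])c3cccc(CS(=O)(=O)C(F)(F)F)c3)nc2/C=C/C(=O)O)cc1`, differs from compound 3 in one place: ((trifluoromethyl)sulfonyl)methyl in place of carboxy on an aromatic carbon. For the measured compounds named here, two measured steps bear on it. Putting a group on this aromatic carbon gave a 4.0-fold higher number from compound 1 to compound 2 (0.60 log units; beyond the scatter) and a 4.1-fold higher number from compound 1 to compound 3 (0.61 log units; beyond the scatter), steps of about the same size, and exchanging one such group for the other gave a 1.0-fold higher number from compound 2 to compound 3 (0.01 log units; within the scatter), a change within the scatter. The present change is again an exchange of one group for another on that carbon, so no step beyond the scatter is expected in this assay, and compound 4 is estimated to land close to compound 3, with the expected step being a 1.0-fold lower number from compound 3 to compound 4 (0.00 log units; within the scatter). Compound 4 is therefore expected to give 150 nM in this assay, in a range from 60 nM to 400 nM.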

Compound 4, inhibition constant: 225 nM
For compound 4 the middle estimate is 1.5-fold (0.18 log units) below the measured one, and the stated range covers the measured number.
By their numbers in this assay, from the lowest: compound 1; then compounds 2, 3 and 4 (each within the scatter of the next).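

In this assay the ((trifluoromethyl)sulfonyl)methyl group joins carboxy and (phenylsulfonyl)amino as a third group on this aromatic carbon that cannot be told apart from the others: a 1.5-fold higher number from compound 3 to compound 4 (0.17 log units; within the scatter) and a 1.5-fold higher number from compound 2 to compound 4 (0.18 log units; within the scatter) both stay within the scatter. The exchange for carboxy removes the hydrogen-bond donor and brings in more heavy atoms, yet no separation appears between compound 3 and compound 4. Set against hydrogen, the new group gives a 6.1-fold higher number from compound 1 to compound 4 (0.78 log units; beyond the scatter) and so, like the other two groups, stands beyond the scatter from compound 1.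

From the compounds shown here alone, whether a single fluorine, a methyl or a simple amine on this carbon would stay close to compound 1 or fall with compounds 2, 3 and 4 remains open. Nothing available explains the gap between hydrogen and these three groups.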